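Ester variation and tolerance on Vero cells

The source may report more compounds than this note shows. Statements on the series, on what has been measured and on what is new or still open speak of the compounds shown alone.

compound 1 `COCCOC(=O)C(O)Cn1cnc2c(N)ncnc21`: > 400 ug/mL
compound 2 `Nc1ncnc2c1ncn2CC(O)C(=O)OC1CCCCC1`: 100 ug/mL

In a functional assay on Vero cells (Chlorocebus sabaeus) for cytotoxicity (a lower number here means that less compound is tolerated, a higher number that more compound is tolerated), compound 1 gives > 400 ug/mL, which is a limit of the assay. Among the measured compounds shown here, compound 2 gives 100 ug/mL in this assay, the only number so far. For the measured compounds named here, the sole measured step is an at least 4.0-fold lower number from compound 1 to compound 2 (0.60 log units; beyond the scatter). Compound 3 `CC(C)COC(=O)C(O)Cn1cnc2c(N)ncnc21` differs from compound 2 by isobutyl in place of cyclohexyl on an oxygen next to a carbonyl group. Going by the values given here, no measured step covers this exact change; the step of an at least 4.0-fold lower number from compound 1 to compound 2 (0.60 log units; beyond the scatter) only shows that the group on this oxygen moves the read-out. Compound 3 is therefore expected to give 200 ug/mL in this assay, between 100 ug/mL and 400 ug/mL. The expected step of a 2.0-fold higher number from compound 2 to compound 3 (0.30 log units; within the scatter) is modest and upward.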

Compound 3, minimum cytotoxic concentration: > 400 ug/mL
Compound 3 ended at the assay's limit (the forecaster's own chance of this, stated with the estimate: 30%); at least 2.0-fold (0.30 log units) between middle value and limit.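

In this assay, isobutyl in place of cyclohexyl on an oxygen next to a carbonyl group gives an at least 4.0-fold higher number from compound 2 to compound 3 (0.60 log units; beyond the scatter), so the drop seen with compound 2 does not extend to this second carbon-only group. Among the three esters, only cyclohexyl, the sole group with a ring, gives a number, while compound 1 and compound 3 both stand at a limit of the assay. The step between those two cannot be read.

Any order among the tolerated esters stays hidden: the limit of > 400 ug/mL in this assay, at which 2 of the 3 values shown sit. Going by these compounds, whether a longer chain or a benzyl group on this oxygen lowers the number as cyclohexyl does remains open.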